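The compounds below may be only part of what the source reports. "The series", "measured", "known", "first", "only" and "open" are said of these compounds alone.

The compounds measured so far, each in an assay on HL-60 cells for agonist activity at N-formyl peptide receptor 3 (Homo sapiens), read by calcium flux; on this read-out higher numbers stand for an effect only at larger amounts of compound and lower numbers for an effect already at smaller amounts:

Compound 1, `COc1ccc(Cc2cc(-c3cccs3)nn(CC(=O)Nc3ccc(Br)cc3)c2=O)cc1`, gives > 50000 nM, which is a limit of the assay and not a number.
Compound 2, `Cc1cc(Cc2ccccc2)c(=O)n(CC(=O)Nc2ccc(Br)cc2)n1`, gives > 50000 nM, again a limit of the assay rather than a number.
Compound 3, `Cc1cc(Cc2ccc(C(F)(F)F)cc2)c(=O)n(CC(=O)Nc2ccc(Br)cc2)n1`, gives > 50000 nM, once more a limit of the assay and not a number.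

So none of the three shows a readable effect, and all sit together at the limit of > 50000 nM in this assay, at which 3 of the 3 values shown sit. Among the compounds with values here, the one change that can be followed within this set, a step that the two limits leave unreadable from compound 2 to compound 3, therefore cannot be read in size or direction, since both of its ends are limits. Within the data shown here, compound 3 thus stands at the limit, with no measured step that places it above or below either neighbour.

The next compound, compound 4, `Cc1cc(Cc2ccc(C(N)=O)cc2)c(=O)n(CC(=O)Nc2ccc(Br)cc2)n1`, differs from compound 3 in one place: carbamoyl in place of trifluoromethyl on an aromatic carbon. Among the measured compounds shown here, no measured step in this assay bears on this kind of change, and the only step that exists, the one from compound 2 to compound 3, is unreadable. With compound 3 at the limit and nothing in the data pointing to a gain, compound 4 is expected to stay at the limit as well, so the step of a number no higher from compound 3 to compound 4 (the limit leaves the size open) is estimated as none beyond the scatter. The estimate for compound 4 in this assay is 50000 nM, with a range from 20000 nM to 200000 nM.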

Compound 4, half-maximal effective concentration: > 50000 nM
Compound 4: a limit, no number; the forecaster's own chance of this, stated with the estimate: 85%; the middle value sits exactly at the limit.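

Compound 4 also ends at a limit of the assay and not at a number, so the steps to it from compound 2 and from compound 3 cannot be read in size or direction: the limit of > 50000 nM in this assay, at which 4 of the 4 values shown sit. The compounds shown leave open whether any change to the shared core gives a measurable effect in this assay at all.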